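Swapping a chloro-pyridine for a dimethyl-pyridine: expected solubility

A few compounds are considered here, and "the series" means these few. Any claim that something is new, unique, unknown or untested is made for them only; others in the source may bear on it.

For the measured compounds named here, compound 3 `Cn1c(COc2cccc(C(=O)O)c2)nc2ccc(Oc3cc(Cl)ccn3)cc21` is one of three compounds measured in a physicochemical assay for solubility, read by HPLC, measured as thermodynamic solubility, with a stated time of 4 h, at pH 6.8; a higher number here means a more soluble compound, a lower number a less soluble compound. Compound 3 gives 11 ug/mL, level at the digits shown with compound 1 `Cn1c(COc2cccc(C(=O)O)c2)nc2cnc(Oc3ccc(Cl)c(F)c3)cc21`, which gives 11 ug/mL; the two together stand lowest of the three. Compound 2 `Cn1c(COc2cccc(C(=O)O)c2)nc2cnc(Oc3ccc4c(c3)OCC4)cc21` gives 79 ug/mL, the highest number. Going by the values given here, the only step between compounds that differ in one place is a 7.2-fold higher number from compound 1 to compound 2 (0.86 log units; beyond the scatter), a change on an oxygen on an aromatic ring, which is the same kind of place as the change considered here, although a different group enters.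

Compound 4 `Cc1ccc(C)c(Oc2ccc3nc(COc4cccc(C(=O)O)c4)n(C)c3c2)n1` is not yet measured. Its difference from compound 3 is 3,6-dimethylpyridin-2-yl in place of 4-chloropyridin-2-yl on an oxygen on an aromatic ring. Among the compounds with values here, no measured pair shows exactly this change. Within the data shown here, the one step that bears on it, from compound 1 to compound 2, replaced a halogen-bearing ring and gave a modest rise; here a chlorine also leaves, but two methyl groups enter. The expected step is therefore small, a 1.4-fold higher number from compound 3 to compound 4 (0.13 log units; within the scatter), and compound 4 is expected to give 15 ug/mL, estimated between 5 ug/mL and 45 ug/mL.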

Compound 4, solubility: 85 ug/mL
Beside the measured number, compound 4's estimate is 5.7-fold (0.75 log units) below it; measured number outside the range, above it.
By their numbers in this assay, from the lowest: compounds 1 and 3 (each within the scatter of the next); then compounds 2 and 4 (each within the scatter of the next).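

Within this assay, a change on an oxygen on an aromatic ring can move the number well beyond the scatter even when the entering and leaving groups both carry one six-membered aromatic ring with a hetero atom: a 7.7-fold higher number from compound 3 to compound 4 (0.89 log units; beyond the scatter). The leaving and entering groups also match in their counts of hydrogen-bond donors and acceptors, so those counts do not separate them; what differs is that a chlorine leaves and two methyl groups enter. Alongside a 7.2-fold higher number from compound 1 to compound 2 (0.86 log units; beyond the scatter), this gives two steps, on different cores, in which a chlorine-bearing ring leaves and the number rises beyond the scatter.

The compounds shown leave open whether losing the chlorine or gaining the methyl groups carries the step, and how an amine on the same ring would compare. Nothing available here gives a measured reason for the rise.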